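Bromo on the Phenyl Ring of Compound 1

The source may report more compounds than this note shows. Statements on the series, on what has been measured and on what is new or still open speak of the compounds shown alone.

Compound 1 `NC1=NC2(CCOCC2)N(OCCCOc2ccccc2)C(N)=N1`: 2460 nM
Compound 2 `Cc1cc(C)cc(OCCCON2C(N)=NC(N)=NC23CCOCC3)c1`: 720 nM
Compound 3 `NC1=NC2(CCSCC2)N(OCCCOc2cccc(Cl)c2Cl)C(N)=N1`: 30 nM

In a functional assay on HL-60 cells (Homo sapiens) for antiproliferative activity, read by MTT assay, with a stated time of 72 h (on this read-out lower numbers stand for stronger inhibition and higher numbers for weaker inhibition), compound 1 stands highest of the three numbers; compound 2 lies nearest, compound 3 furthest. Compound 4 `NC1=NC2(CCOCC2)N(OCCCOc2ccc(Br)cc2)C(N)=N1` differs from compound 1 by bromo in place of hydrogen on an aromatic carbon. Going by the values given here, only one measured step concerns a change on the same phenyl ring: a 3.4-fold lower number from compound 1 to compound 2 (0.53 log units; beyond the scatter). Compound 3 carries two chlorines on that ring but also a different core, so its value alone shows that halogenated rings can go with low numbers. From this, compound 4 is expected to give a modest step downward, a 3.1-fold lower number from compound 1 to compound 4 (0.49 log units; beyond the scatter). The estimate for compound 4 is 800 nM, within 300 nM to 2500 nM.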

Compound 4, half-maximal inhibitory concentration: 310 nM
Compound 4: middle estimate off by 2.6-fold (0.41 log units), on the high side, within the range that was stated.
By their numbers in this assay, from the lowest: compound 3; then compound 4; then compound 2; then compound 1.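

In this assay, a single bromo on the phenyl ring, para to a large group, gives a 7.9-fold lower number from compound 1 to compound 4 (0.90 log units; beyond the scatter). The 4-bromophenyl group also goes further than the 3,5-dimethylphenyl group, with a 2.3-fold lower number from compound 2 to compound 4 (0.37 log units; beyond the scatter), so on this core the number depends on which group the ring carries and not only on whether it carries one. Nothing available here explains why bromo lowers the number. As far as these compounds go, whether a methoxy group or an amine in the same place would lower it as well stays open. So does whether bromo would give a similar step on the core of compound 3.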